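The source may report more compounds than this note shows. Statements on the series, on what has been measured and on what is new or still open speak of the compounds shown alone.

Working notes on the series built on the core of compound 1 (`FC(F)(F)c1ccc(-c2ccc(-c3ccc(-c4nc5ccccc5[nH]4)cc3)cc2)cc1`), read in a functional assay on COLO 205 cells (Homo sapiens) for inhibition, read by sulforhodamine B assay; a higher number here means a weaker inhibitor of growth, a lower number a stronger inhibitor of growth. Compound 1 gives 33900 nM. Compound 2 (`COc1ccc(-c2ccc(-c3ccc(-c4nc5ccccc5[nH]4)cc3)cc2)cc1`) gives 45200 nM, and a 1.3-fold higher number from compound 1 to compound 2 (0.12 log units; within the scatter). Compound 3 (`CN(C)c1ccc(-c2ccc(-c3ccc(-c4nc5ccccc5[nH]4)cc3)cc2)cc1`) gives 100000 nM, the highest number of the three and so the weakest growth inhibitor measured so far.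

Compound 4 (`COc1ccc(-c2ccc(-c3ccc(-c4nc5ccccc5[nH]4)cc3)cc2)cc1OC`) carries 3,4-dimethoxyphenyl in place of 4-(dimethylamino)phenyl, on an aromatic carbon para to a large group: 3,4-dimethoxyphenyl in place of 4-(dimethylamino)phenyl on an aromatic carbon.

The closest measured step is a 2.2-fold higher number from compound 2 to compound 3 (0.34 log units; beyond the scatter), which exchanges methoxy for dimethylamino at this end of the molecule. The new change runs the other way, so that step suggests a move back towards a lower number. The step of a 2.9-fold higher number from compound 1 to compound 3 (0.47 log units; beyond the scatter) is of similar modest size, so the three substituents measured so far span only a narrow range. For the measured compounds named here, no measured step covers the second methoxy of the 3,4-dimethoxyphenyl group, which widens the uncertainty.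

The expected change is a 2.1-fold lower number from compound 3 to compound 4 (0.32 log units; beyond the scatter), a modest move towards stronger growth inhibition. For compound 4 the estimated value is 48000 nM, with an expected range of 24000 nM to 100000 nM.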

Compound 4, concentration for 50% growth inhibition: 41200 nM
The estimate for compound 4 lay 1.2-fold (0.07 log units) above the measured number; low and high end bracket the measured number.
By their numbers in this assay, from the lowest: compounds 1, 4 and 2 (each within the scatter of the next); then compound 3.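

The second methoxy group adds nothing readable in this assay: methoxy in place of hydrogen on an aromatic carbon gives a 1.1-fold lower number from compound 2 to compound 4 (0.04 log units; within the scatter), so compound 4 cannot be told apart from the single-methoxy compound. The comparison with the trifluoromethyl compound is also within the scatter, with 3,4-dimethoxyphenyl in place of 4-(trifluoromethyl)phenyl giving a 1.2-fold higher number from compound 1 to compound 4 (0.08 log units; within the scatter), which leaves compounds 1, 2 and 4 as one group at this position, with no group among the three ahead of the others. Only compound 3 stands apart from all of them, as a 2.4-fold lower number from compound 3 to compound 4 (0.39 log units; beyond the scatter) now confirms for a second replacement of 4-(dimethylamino)phenyl, and nothing available explains this separation.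

As far as these compounds go, it remains open whether the higher number belongs to dimethylamino specifically or would also appear with a primary amine, a morpholine or another nitrogen-bearing group at this end of the molecule. A carboxylic acid or a longer alkoxy chain on this ring would test whether any substituent here can move the number clearly below the group formed by compounds 1, 2 and 4.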